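Pyridyl to carboxyphenyl on the tetrazole of an aryloxy ketone

The source may hold more compounds than are shown below. What is called first, only, known or untested is meant among the compounds shown, and "the series" means these compounds.

Measured compounds:
compound 1, `CCCCCCCCc1ccc(OCC(=O)Cn2nnc(C)n2)cc1`, 27 nM
compound 2, `CCCCCCCCc1ccc(OCC(=O)Cn2nnc(-c3cccc(S(=O)(=O)N(C)C)c3)n2)cc1`, 420 nM
compound 3, `CCCCCCCCc1ccc(OCC(=O)Cn2nnc(-c3ccccn3)n2)cc1`, 18 nM

In an assay on microsomes from brain for inhibition of Fatty-acid amide hydrolase 1 (Rattus norvegicus), read by fluorescence and HPLC, with a stated time of 60 min (a lower number here means a stronger inhibitor, a higher number a weaker inhibitor), compound 3 gives the lowest of the three numbers. Its nearest neighbour is compound 1, separated by a 1.5-fold lower number from compound 1 to compound 3 (0.18 log units; within the scatter), and its furthest is compound 2, separated by a 23-fold lower number from compound 2 to compound 3 (1.37 log units; beyond the scatter).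

Compound 4, `CCCCCCCCc1ccc(OCC(=O)Cn2nnc(-c3ccc(C(=O)O)cc3)n2)cc1`, is not yet measured. It differs from compound 3 in one place: 4-carboxyphenyl in place of pyridin-2-yl on an aromatic carbon.

Going by the values given here, two measured steps bear on this change. The one substituted phenyl ring that has been measured, in compound 2, gave a 16-fold higher number from compound 1 to compound 2 (1.19 log units; beyond the scatter) and, read the other way, a 23-fold lower number from compound 2 to compound 3 (1.37 log units; beyond the scatter). Compound 4 again carries a substituted phenyl ring at the same position, though its substituent is a carboxylic acid rather than a dimethylsulfamoyl group, so a step of the same sign is expected in this assay, of a size beyond the scatter but uncertain. The expected step is a 14-fold higher number from compound 3 to compound 4 (1.14 log units; beyond the scatter), and compound 4 is therefore estimated at 250 nM, within a range of 60 nM to 1200 nM.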

Compound 4, half-maximal inhibitory concentration: 90 nM
Beside the measured number, compound 4's estimate is 2.8-fold (0.44 log units) above it; low and high end bracket the measured number.
By their numbers in this assay, from the lowest: compounds 3 and 1 (each within the scatter of the next); then compound 4; then compound 2.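

In this assay, the 4-carboxyphenyl group gives a better result at this position than the only earlier substituted phenyl ring, with a 4.7-fold lower number from compound 2 to compound 4 (0.67 log units; beyond the scatter) and so a phenyl ring here does not fix the number by itself. It still falls behind both smaller groups, with a 5.0-fold higher number from compound 3 to compound 4 (0.70 log units; beyond the scatter) and a 3.3-fold higher number from compound 1 to compound 4 (0.52 log units; beyond the scatter) in the same assay, while pyridin-2-yl and methyl remain within the scatter of each other. Nothing measured here accounts for these differences.

The two phenyl groups differ both in their substituent and in where it sits on the ring, and the compounds shown cannot separate those two changes. Going by these compounds, how an unsubstituted phenyl ring, a 3-carboxyphenyl group or the methyl ester of the carboxylic acid would read here remains open.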